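A few compounds are considered here, and "the series" means these few. Any claim that something is new, unique, unknown or untested is made for them only; others in the source may bear on it.

Working notes on the series. In an assay on cells for inhibition of MAP kinase-interacting serine/threonine-protein kinase 1 (Homo sapiens), read by mobility shift assay, with stated times of 10 min and 60 min, in the presence of a further agent that is not named here (a higher number here means a weaker inhibitor, a lower number a stronger inhibitor), compound 1 `CNC(=O)c1cncc(-c2ccc(C(N)=O)c(OC(C)C)c2)c1` gives 1900 nM, compound 2 `NCCOc1cc(-c2cccnc2)ccc1C(N)=O` gives 820 nM and compound 3 `CC(C)Oc1cc(-c2cncc(-c3c[nH]nc3C3CC3)c2)ccc1C(N)=O` gives 130 nM. Compound 2 therefore stands second highest of the three numbers: the gap to compound 1 is beyond the scatter, as is the larger gap to compound 3.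

For the measured compounds named here, the one measured step alters a different place on the shared core: a 15-fold lower number from compound 1 to compound 3 (1.16 log units; beyond the scatter). Going by the values given here, no measured pair differs only at the oxygen on the aromatic ring, so the change to compound 4 `NC(=O)c1ccc(-c2cccnc2)cc1OC1CCC1` is untested here. Compound 4 differs from compound 2 as follows: cyclobutyl in place of 2-aminoethyl on an oxygen on an aromatic ring. Both compounds with isopropyloxy at that oxygen, compound 1 and compound 3, span the whole range of numbers seen, so the oxygen substituent is not the main driver in this set. For compound 4 a step not beyond the scatter is therefore expected, a 1.4-fold lower number from compound 2 to compound 4 (0.14 log units; within the scatter), with wide uncertainty. The expected value for compound 4 is 600 nM, with a range of 200 nM to 2000 nM.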

Compound 4, half-maximal inhibitory concentration: 1900 nM
Beside the measured number, compound 4's estimate is 3.2-fold (0.50 log units) below it; the range from low to high includes it.
By their numbers in this assay, from the lowest: compound 3; then compound 2; then compounds 1 and 4 (each within the scatter of the next).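

In this assay, the oxygen on an aromatic ring proves to be a position that moves the number: cyclobutyl in place of 2-aminoethyl gives a 2.3-fold higher number from compound 2 to compound 4 (0.36 log units; beyond the scatter). For the compounds shown here, the earlier compounds offered no pair differing only at this oxygen, so this is the first direct reading of the position, and it favours 2-aminoethyl over cyclobutyl, though only modestly. No measurement available here bears on the reason for this step.

As far as these compounds go, this single pair cannot separate the loss of the chain's terminal amine from the entry of the four-membered carbon ring, and what a 3-aminopropyl chain or an open-chain butyl at this oxygen would give remains open. From the compounds shown here alone, whether the step carries over to the core of compound 3 also remains open.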